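The source may hold more compounds than are shown below. What is called first, only, known or untested is meant among the compounds shown, and "the series" means these compounds.

In a functional assay on MV cells (Homo sapiens) for inhibition, read by sulforhodamine B assay (a higher number here means a weaker inhibitor, a lower number a stronger inhibitor), three compounds have been measured:

compound 1 `C#CC(=O)N1C(C(CC)CCCC)SC[C@@H]1C(=O)OCC` gives 1600 nM
compound 2 `C#CC(=O)N1C(c2ccc(OC)cc2)SC[C@@H]1C(=O)OCC` gives 700 nM
compound 3 `C#CC(=O)N1C(CC(C)CC(C)(C)C)SC[C@@H]1C(=O)OCC` gives 1100 nM

Compound 2 has the lowest of the three numbers. Its nearest neighbour is compound 3, whose number is higher but within the scatter; compound 1 lies furthest, beyond the scatter. Compound 4 `C#CC(=O)N1C(c2ccccc2)SC[C@@H]1C(=O)OCC` differs from compound 2 by hydrogen in place of methoxy on an aromatic carbon. Among the compounds with values here, no measured pair shows this change, so its size cannot be read from the data. The expected step from compound 2 to compound 4 is a 1.3-fold higher number from compound 2 to compound 4 (0.11 log units; within the scatter), that is, none beyond the scatter. Compound 4 is therefore estimated at 900 nM in this assay, within a range from 400 nM to 2000 nM.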

Compound 4, half-maximal inhibitory concentration: 400 nM
The estimate for compound 4 lay 2.3-fold (0.35 log units) above the measured number; the measured number falls inside the stated range.
By their numbers in this assay, from the lowest: compounds 4, 2, 3 and 1 (each within the scatter of the next, the first and the last beyond it).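

In this assay, hydrogen in place of methoxy on the aromatic carbon gives a 1.8-fold lower number from compound 2 to compound 4 (0.24 log units; within the scatter), so compound 2 does not depend on methoxy for its number. At the saturated ring carbon, phenyl in place of 1-ethylpentyl gives a 4.0-fold lower number from compound 1 to compound 4 (0.60 log units; beyond the scatter), the first single-place change shown to reach beyond the scatter. No evidence explains either step. From the compounds shown here alone, whether chlorine or a dimethylamino group on that aromatic carbon would shift the number remains open. So does whether a cyclohexyl group on the saturated ring carbon would match phenyl.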